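Swapping acetyl(methyl)amino for 4-(carboxymethyl)phenyl in the series

This account rests on a few compounds, and the source may have more. Where it says the series, first, only, none or still open, it means among the compounds named here.

In an ADME assay on the whole organism for pharmacokinetics, with Mus musculus as the target, at a dose of 10 mg/kg by the oral route (a higher number here means more compound in the circulation at the dose given, a lower number less compound in the circulation), compound 2 (`CC(=O)N(C)c1ccc(OCc2ccc(C(F)(F)F)c(O)c2C(=O)OC(C)(C)C)cc1`) gives 2280 nM and compound 1 (`CC(=O)N(C)c1ccc(OCc2ccc(C(F)(F)F)cc2C(=O)OC(C)(C)C)cc1`) gives 4010 nM, so the two stand within the scatter of each other. Compound 3 (`CC(C)(C)OC(=O)c1c(COc2ccc(-c3ccc(CC(=O)O)cc3)cc2)ccc(C(F)(F)F)c1O`) differs from compound 2 as follows: 4-(carboxymethyl)phenyl in place of acetyl(methyl)amino on an aromatic carbon. Going by the values given here, the only measured step, a 1.8-fold lower number from compound 1 to compound 2 (0.25 log units; within the scatter), concerns hydroxy in place of hydrogen, a different change, and offers little guidance here. The expected step is a 1.5-fold lower number from compound 2 to compound 3 (0.18 log units; within the scatter), with none beyond the scatter expected in this assay. For compound 3 the estimate is 1500 nM, with an expected range of 300 nM to 7500 nM.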

Compound 3, maximal plasma concentration: 17700 nM
Compound 3: middle estimate off by 12-fold (1.07 log units), on the low side, and the stated range ends below it.
By their numbers in this assay, from the lowest: compounds 2 and 1 (each within the scatter of the next); then compound 3.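

In this assay the place held by acetyl(methyl)amino proves able to move the maximal plasma concentration: 4-(carboxymethyl)phenyl there gives a 7.8-fold higher number from compound 2 to compound 3 (0.89 log units; beyond the scatter) in the series. The hydroxy change from compound 1 to compound 2 stayed within the scatter, so this is the first step shown to lie beyond it. Nothing measured here bears on the reason for the step.

On these data alone, whether the step follows the added aromatic ring or the carboxymethyl on it stays open. A plain phenyl or a 4-(aminomethyl)phenyl in this place would separate the two.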